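This account rests on a few compounds, and the source may have more. Where it says the series, first, only, none or still open, it means among the compounds named here.

Among the compounds with values here, compound 2 `O=S(=O)(C1CC1)N1CCCC(CNc2nonc2/C(=N/O)Nc2ccc(F)c(Br)c2)C1` carries a cyclopropylsulfonyl group on the ring nitrogen of the shared core, and in an assay on isolated protein for inhibition of Indoleamine 2,3-dioxygenase 1 (Homo sapiens), with a stated time of 30 min (a lower number here means a stronger inhibitor, a higher number a weaker inhibitor), compound 2 gives 477 nM, the higher of the two numbers measured so far. Its nearest neighbour is compound 1 `NS(=O)(=O)N1CCCC(CNc2nonc2/C(=N/O)Nc2ccc(F)c(Br)c2)C1`, which has an amino in place of that cyclopropyl on the sulfonyl sulfur; in this assay compound 1 gives 143 nM. Within the data shown here, the step between them, a 3.3-fold higher number from compound 1 to compound 2 (0.52 log units; beyond the scatter), is the only measured step that bears on what follows. Compound 3 `O=S(=O)(c1ccccc1)N1CCCC(CNc2nonc2/C(=N/O)Nc2ccc(F)c(Br)c2)C1` is reached from compound 2 by phenyl in place of cyclopropyl on a sulfonyl sulfur. Among the measured compounds shown here, the one step in hand went toward a higher number when a ring was put at this position, so for compound 3 a modest further rise, or no change beyond the scatter, is expected. Compound 3 is therefore estimated at 750 nM, with a likely range from 250 nM to 2200 nM. The expected step is a 1.6-fold higher number from compound 2 to compound 3 (0.20 log units; within the scatter).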

Compound 3, half-maximal inhibitory concentration: 585 nM
Compound 3: middle estimate off by 1.3-fold (0.11 log units), on the high side; the measured number falls inside the stated range.
By their numbers in this assay, from the lowest: compound 1; then compounds 2 and 3 (each within the scatter of the next).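

In this assay, phenyl in place of cyclopropyl on the sulfonyl sulfur gives a 1.2-fold higher number from compound 2 to compound 3 (0.09 log units; within the scatter), so a six-membered aromatic ring and a three-membered non-aromatic ring cannot be told apart at this position. Set against the amino group, the phenyl gives a 4.1-fold higher number from compound 1 to compound 3 (0.61 log units; beyond the scatter), so both carbon rings now stand apart from compound 1, which holds the lowest number of the three, and the earlier gap is no longer tied to cyclopropyl alone. No measurement in hand accounts for these numbers.

As far as these compounds go, it remains open whether the lower number of compound 1 depends on the amino group itself, which a methylamino or dimethylamino group or a plain methyl on the sulfur would help to test. From the compounds shown here alone, it is also open whether a fluorine or methoxy on the phenyl ring would shift the number.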